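The compounds below may be only part of what the source reports. "The series", "measured", "known", "first", "only" and "open" are said of these compounds alone.

Compound 1 `CCN1CCN(c2cc(C)c3cc(NC(=O)c4cc(Cl)cc(Cl)c4)ccc3n2)CC1` gives 6090 nM in a functional assay on MCF7 cells (Homo sapiens) for antiproliferative activity, read by MTT assay, with a stated time of 72 h (a higher number here means a weaker inhibitor, a lower number a stronger inhibitor), the highest of the three numbers in hand. Compound 2 `Cc1cc(N2CCN(C(C)C)CC2)nc2ccc(NC(=O)c3ccc(Cl)c(Cl)c3)cc12` gives 1710 nM and compound 3 `Cc1cc(N2CCN(C)CC2)nc2ccc(NC(=O)c3ccc(Cl)c(Cl)c3)cc12` gives 3000 nM. Within the data shown here, the only measured step, a 1.8-fold higher number from compound 2 to compound 3 (0.24 log units; within the scatter), concerns the amine nitrogen in a ring, not the aryl amide, so it does not bear on the change from compound 1 to compound 4 `CCN1CCN(c2cc(C)c3cc(NC(=O)c4ccc(Br)cc4)ccc3n2)CC1`: 4-bromophenyl in place of 3,5-dichlorophenyl on a carbonyl carbon. Among the measured compounds shown here, compound 1 and compound 3 differ in two places, and their values show only that compound 1 sits higher. For the measured compounds named here, no measured step touches the aryl amide; the expected step of a 1.1-fold higher number from compound 1 to compound 4 (0.06 log units; within the scatter) is therefore kept small, within the scatter, with no basis for a direction. Compound 4 is estimated at 7000 nM, range 2500 nM to 20000 nM.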

Compound 4, half-maximal inhibitory concentration: 5940 nM
Beside the measured number, compound 4's estimate is 1.2-fold (0.07 log units) above it, within the range that was stated.
By their numbers in this assay, from the lowest: compounds 2, 3, 4 and 1 (each within the scatter of the next, the first and the last beyond it).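

Among these compounds, this is the first measured step at the aryl amide: in this assay, 4-bromophenyl in place of 3,5-dichlorophenyl on a carbonyl carbon gives a 1.0-fold lower number from compound 1 to compound 4 (0.01 log units; within the scatter). With the rest of compound 1 held fixed, these two halogen-bearing phenyl groups therefore cannot be told apart at this position, and neither one separates from the other in this assay.

As far as these compounds go, whether an amine or a carboxylic acid on this phenyl, or a longer chain in its place on the carbonyl carbon, would depart from these values stays open. No evidence at hand explains why the two groups read alike.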